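Aryl variation at the hydrazone carbon: compound 3 to compound 4

The compounds below may be only part of what the source reports. "The series", "measured", "known", "first", "only" and "open" are said of these compounds alone.

The shared core carries a dimethylaminoethyl-substituted triazole on a pyridine, linked through an ether to a fluorinated aniline that ends in a semicarbazone. Three aryl variants at the hydrazone carbon have numbers. In a functional assay on NCI-H460 cells (Homo sapiens) for cytotoxicity, read by MTT assay, with a stated time of 72 h (a higher number here means a weaker inhibitor, a lower number a stronger inhibitor), compound 1 `CN(C)CCn1cnnc1-c1cc(Oc2ccc(NC(=O)N/N=C/c3cccc(Br)c3)cc2F)ccn1` gives 520 nM; compound 2 `CN(C)CCn1cnnc1-c1cc(Oc2ccc(NC(=O)N/N=C/c3ccc(O)c(F)c3)cc2F)ccn1` gives 2620 nM; compound 3 `CN(C)CCn1cnnc1-c1cc(Oc2ccc(NC(=O)N/N=C/c3ccccc3O[N+](=O)[O-])cc2F)ccn1` gives 1270 nM. Compound 3 therefore stands second highest of the three, with a 2.4-fold higher number from compound 1 to compound 3 (0.39 log units; beyond the scatter) and a 2.1-fold lower number from compound 2 to compound 3 (0.31 log units; beyond the scatter), both modest steps beyond the scatter.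

Compound 4 `COc1cc(/C=N/NC(=O)Nc2ccc(Oc3ccnc(-c4nncn4CCN(C)C)c3)c(F)c2)cc(OC)c1OC` differs from compound 3 in one place: 3,4,5-trimethoxyphenyl in place of 2-(nitrooxy)phenyl on a carbon with a double bond to nitrogen.

Among the compounds with values here, no measured step involves the entering group, so nothing bears on it directly. What the three measured steps show is that swapping the aryl group on the carbon with a double bond to nitrogen has moved this assay only modestly: a 5.0-fold higher number from compound 1 to compound 2 (0.70 log units; beyond the scatter) is the widest spread. A change of similar size, in either direction, is expected for a 1.3-fold lower number from compound 3 to compound 4 (0.10 log units; within the scatter), with no strong reason to favour one direction.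

Compound 4 is therefore estimated at 1000 nM in this assay, with a range of 350 nM to 3000 nM spanning the measured aryl variants.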

Compound 4, half-maximal inhibitory concentration: 2770 nM
Compound 4: the middle estimate sits 2.8-fold (0.44 log units) below what was measured, and the stated range covers the measured number.
By their numbers in this assay, from the lowest: compound 1; then compound 3; then compounds 2 and 4 (each within the scatter of the next).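

In this assay, 3,4,5-trimethoxyphenyl on the carbon with a double bond to nitrogen gives a 2.2-fold higher number from compound 3 to compound 4 (0.34 log units; beyond the scatter) and a 5.3-fold higher number from compound 1 to compound 4 (0.73 log units; beyond the scatter), which extends the set of aryl variants without moving the series beyond a modest step. The comparison with the 3-fluoro-4-hydroxyphenyl variant gives a 1.1-fold higher number from compound 2 to compound 4 (0.02 log units; within the scatter), so two differently substituted aryl groups now stand level, and compound 1, with 3-bromophenyl, is the strongest of the four, with its steps to all the others printed as beyond the scatter. Compound 2, compound 3 and compound 4 all carry oxygen on the aryl ring and all give higher numbers than compound 1, but with a single aryl group lacking oxygen this is only an observation on four compounds, and nothing available gives a reason for these differences.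

Open, as far as these compounds go, is whether an unsubstituted phenyl or a chlorophenyl would stand nearer compound 1 or nearer compound 4. Also open, from the compounds shown here alone, is how an aryl group bearing an amine or a carboxylic acid would read at this carbon.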